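The compounds below may be only part of what the source reports. "The series", "measured", "known", "first", "only" and "open" are said of these compounds alone.

Measured in a functional assay on HepG2 cells (Homo sapiens) for antiproliferative activity, read by MTT assay, with a stated time of 24 h; on this read-out lower numbers stand for stronger inhibition and higher numbers for weaker inhibition:
- Compound 1 `C=CCc1cc(-c2cccc(C(F)(F)F)c2)ccc1O`: 58300 nM
- Compound 2 `C=CCc1cc(-c2cccc([N+](=O)[O-])c2)ccc1O`: > 100000 nM (a limit)
- Compound 3 `C=CCc1cc(-c2ccccc2)ccc1O`: > 100000 nM (a limit)

Compound 3 has only a limit and no exact number, and it sits at the limit of > 100000 nM in this assay, at which 2 of the 3 values shown sit. Compound 4 `C=CCc1cc(-c2cccc(SC)c2)ccc1O` puts methylsulfanyl in place of hydrogen on an aromatic carbon, meta to a large group: methylsulfanyl in place of hydrogen on an aromatic carbon. Going by the values given here, two steps bear on this: an at least 1.7-fold higher number from compound 1 to compound 3 (0.23 log units; that floor lies within the scatter), with hydrogen replacing trifluoromethyl, and an at least 1.7-fold higher number from compound 1 to compound 2 (0.23 log units; that floor lies within the scatter), with nitro replacing trifluoromethyl. Both floors lie within the scatter, so they give only weak guidance. Compound 1 does give a readable value, 58300 nM, so a small move towards stronger inhibition in this assay is expected, as the estimated at least 1.2-fold lower number from compound 3 to compound 4 (0.09 log units; that floor lies within the scatter). For compound 4 the estimated value is 80000 nM, with an expected range from 35000 nM to 160000 nM.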

Compound 4, half-maximal inhibitory concentration: > 100000 nM
Compound 4 gave a limit, no number; the forecaster's own chance of this, stated with the estimate: 55%; middle value at least 1.2-fold (0.09 log units) from the limit.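

Methylsulfanyl, a sulfur-containing group, joins hydrogen and nitro at this position in giving only a limit, so trifluoromethyl remains the only group shown with a measured number. Going by these compounds alone, the steps to compound 4 from compound 2 and compound 3 cannot be read, with limits at both ends, and the one readable step is small: an at least 1.7-fold higher number from compound 1 to compound 4 (0.23 log units; that floor lies within the scatter). The values now gather at a single limit: the limit of > 100000 nM in this assay, at which 3 of the 4 values shown sit.

On these data alone, whether compound 1 truly differs from the other three remains open. So does how an amine or a carboxylic acid at this position would read.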